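The source may hold more compounds than are shown below. What is called first, only, known or untested is meant among the compounds shown, and "the series" means these compounds.

Measured compounds:
- compound 1, `COC(=O)c1ccc(C2SCC(=O)N2c2ccc(N3CCN(S(=O)(=O)c4ccc(F)cc4)CC3)cn2)c(OC)c1`, with 78300 nM
- compound 2, `COC(=O)c1ccc(C2SCC(=O)N2c2ccc(N3CCN(S(=O)(=O)c4ccccc4)CC3)cn2)c(OC)c1`, with 52900 nM

Both numbers come from a functional assay on Jurkat cells (Homo sapiens) for antiproliferative activity, read by MTT assay and trypan blue exclusion, with a stated time of 72 h; a lower number here means a stronger inhibitor, a higher number a weaker inhibitor. Compound 2 holds the lowest of the two numbers recorded so far, but its nearest neighbour, compound 1, differs from it only by hydrogen in place of fluoro on an aromatic carbon, and that step, a 1.5-fold lower number from compound 1 to compound 2 (0.17 log units; within the scatter), lies within the scatter. The two values therefore do not separate.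

Compound 3, `COC(=O)c1ccc(C2SCC(=O)N2c2ccc(N3CCNCC3)cn2)c(OC)c1`, has not yet been measured. Compared with compound 2 it shows (hydrogen in place of phenylsulfonyl on an amine nitrogen in a ring). Among the measured compounds shown here, the only measured step concerns a change on the aromatic ring of the phenylsulfonyl group, not its removal, so nothing recorded bears directly on the step from compound 2 to compound 3. For the measured compounds named here, with no relevant precedent, no shift beyond the scatter is expected in this assay , though the uncertainty is wide. The estimated step is a 1.1-fold higher number from compound 2 to compound 3 (0.05 log units; within the scatter). For compound 3 the expected value in this assay is 60000 nM, with a range from 15000 nM to 200000 nM.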

Compound 3, half-maximal inhibitory concentration: 19300 nM
The estimate for compound 3 lay 3.1-fold (0.49 log units) above the measured number; measured number inside the range.
By their numbers in this assay, from the lowest: compound 3; then compounds 2 and 1 (each within the scatter of the next).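

In this assay, taking the whole phenylsulfonyl group off the amine nitrogen in the ring and leaving hydrogen there gives a 2.7-fold lower number from compound 2 to compound 3 (0.44 log units; beyond the scatter), and taking off the (4-fluorophenyl)sulfonyl group gives a 4.1-fold lower number from compound 1 to compound 3 (0.61 log units; beyond the scatter), both modest. The earlier pair changed only the aromatic ring of the sulfonyl group and did not separate, whereas replacing the entire group does, so compound 3, with hydrogen on that nitrogen, holds the lowest number of the three and lies beyond the scatter of both others. Nothing available explains this step.

The compounds shown leave open whether the shift follows the loss of the sulfonyl link or of the aromatic ring, which a methanesulfonyl, acetyl or benzyl group on the same nitrogen would help to separate. They also leave open whether compound 3, at 19300 nM, would move further with a different group elsewhere on the shared core, such as a carboxylic acid in place of the methyl ester.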